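The compounds below may be only part of what the source reports. "The series", "measured", "known", "first", "only" and "open" are said of these compounds alone.

Measured compounds:
compound 1 `COc1ccc(-c2nc(-c3c[nH]c4ccccc34)co2)cc1OC` — 759000 nM
compound 2 `Oc1ccc(-c2nc(-c3c[nH]c4ccccc34)co2)cc1` — 580000 nM
compound 3 `COc1ccc(-c2nc(-c3c[nH]c4ccccc34)co2)cc1` — 43800 nM

In a functional assay on MCF7 cells (Homo sapiens) for cytotoxicity, read by MTT assay, with a stated time of 48 h (a lower number here means a stronger inhibitor, a higher number a weaker inhibitor), compound 2 gives 580000 nM, the second highest of the three numbers; its nearest neighbour is compound 1, within the scatter, and its furthest is compound 3. The two steps that reach compound 3 are both large: a 13-fold lower number from compound 2 to compound 3 (1.12 log units; beyond the scatter) and a 17-fold lower number from compound 1 to compound 3 (1.24 log units; beyond the scatter). Both steps alter only the substituents on the six-membered ring that compound 2 carries on the shared core, and both show that small changes there move the number by a large amount.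

Compound 4 `C=Cc1nc(-c2c[nH]c3ccccc23)co1` is not yet measured. The change from compound 2 is vinyl in place of 4-hydroxyphenyl on an aromatic carbon. Neither measured step bears directly on this change, since the group that is altered in those steps is the one that leaves here; they tell nothing about what happens when that ring is gone and only a vinyl remains. Among the measured compounds shown here, with no comparable step available, no step beyond the scatter is expected in either direction in this assay, but the uncertainty is wide, and the estimate means a 1.0-fold higher number from compound 2 to compound 4 (0.01 log units; within the scatter). Compound 4 is therefore expected to give about 600000 nM, between 150000 nM and 2500000 nM.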

Compound 4, half-maximal inhibitory concentration: 103000 nM
For compound 4 the middle estimate is 5.8-fold (0.77 log units) above the measured one; the whole stated range lies above it.
By their numbers in this assay, from the lowest: compound 3; then compound 4; then compounds 2 and 1 (each within the scatter of the next).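

In this assay, among the compounds shown here, the earlier steps changed only the substituents on the six-membered ring, whereas this change removes the whole 4-hydroxyphenyl group from the aromatic carbon of the five-membered aromatic ring, and a 5.6-fold lower number from compound 2 to compound 4 (0.75 log units; beyond the scatter). The number therefore does not depend on an aromatic ring at this carbon: vinyl, with no ring and with 0 hydrogen-bond donors and 0 hydrogen-bond acceptors, gives a lower number than the 4-hydroxyphenyl group it replaces. The 4-methoxyphenyl group still gives the lowest number of the series, since compound 4 at 103000 nM stands above compound 3 at 43800 nM, so vinyl improves on the 4-hydroxyphenyl group without matching the 4-methoxyphenyl group, and nothing available explains the effect of this change.

Open, from the compounds shown here alone, is whether the double bond of the vinyl group matters, which an ethyl group on the same carbon would test, and whether a longer chain or an amine there would move the number further in either direction. Also open, going by these compounds, is whether any group at this carbon can give a number below that of compound 3.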